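The source may report more compounds than this note shows. Statements on the series, on what has been measured and on what is new or still open speak of the compounds shown alone.

Measured in an ADME assay on the whole organism (strain FVB) for pharmacokinetics, with Mus musculus as the target, read by LC-MS, at a dose of 30 mg/kg by the oral route; a lower number here means less compound in the circulation, a higher number more compound in the circulation at the dose given:
compound 1 `CC(C)(O)CNCCCOc1ccc([C@H]2CC[C@]3(CC2)OOC2(O3)C3CC4CC(C3)CC2C4)cc1`: 1210 nM
compound 2 `CC(C)(O)CN1CCC(Oc2ccc([C@H]3CC[C@]4(CC3)OOC3(O4)C4CC5CC(C4)CC3C5)cc2)CC1`: 1810 nM
compound 3 `N[C@H]1CC[C@@H](Oc2ccc([C@H]3CC[C@]4(CC3)OOC3(O4)C4CC5CC(C4)CC3C5)cc2)CC1`: 1170 nM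

Compound 3 stands within the scatter of both other compounds, as the measured steps show: a 1.0-fold lower number from compound 1 to compound 3 (0.01 log units; within the scatter) and a 1.5-fold lower number from compound 2 to compound 3 (0.19 log units; within the scatter). Compound 4 `CC1(C)CC(O)(COc2ccc([C@H]3CC[C@]4(CC3)OOC3(O4)C4CC5CC(C4)CC3C5)cc2)CC(C)(C)N1` keeps the shared core but carries (4-hydroxy-2,2,6,6-tetramethylpiperidin-4-yl)methyl in place of 4-aminocyclohexyl on an oxygen on an aromatic ring. Within the data shown here, no measured step makes this exact change. The closest evidence is that swapping groups on that oxygen has so far given only small steps, the third being a 1.5-fold higher number from compound 1 to compound 2 (0.17 log units; within the scatter). All three stayed within the scatter, so no step beyond the scatter is expected in this assay. The expected step is a 1.1-fold higher number from compound 3 to compound 4 (0.05 log units; within the scatter). The estimate for compound 4 is 1300 nM, with an expected range from 500 nM to 3200 nM.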

Compound 4, maximal plasma concentration: 1000 nM
Estimate against measurement, compound 4: 1.3-fold (0.11 log units) above; low and high end bracket the measured number.
By their numbers in this assay, from the lowest: compounds 4, 3, 1 and 2 (each within the scatter of the next).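

At the oxygen on an aromatic ring, even the larger (4-hydroxy-2,2,6,6-tetramethylpiperidin-4-yl)methyl group, with its 12 heavy atoms and 2 hydrogen-bond donors, leaves this assay within the scatter of all three earlier compounds: a 1.2-fold lower number from compound 3 to compound 4 (0.07 log units; within the scatter), a 1.8-fold lower number from compound 2 to compound 4 (0.26 log units; within the scatter) and a 1.2-fold lower number from compound 1 to compound 4 (0.08 log units; within the scatter). So this position has now taken four quite different amine-bearing groups without a step beyond the scatter. Nothing measured here explains that result.

On these data alone, whether a carboxylic acid on the same oxygen would also stay within the scatter remains open. So does the effect of a change elsewhere on the shared core.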